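Swapping Fluoro for Trifluoromethyl in a Seizure Model

The source may report more compounds than this note shows. Statements on the series, on what has been measured and on what is new or still open speak of the compounds shown alone.

Going by the values given here, compound 2 `CC(C(=O)N1CCN(c2cccc(F)c2)CC1)N1C(=O)CCC1=O` is tested in a functional assay on the whole organism (strain Swiss) with Mus musculus as the target, in the maximal electroshock model, with a stated time of 0.25 h, at a dose of 300 mg/kg by the intraperitoneal route (on this read-out higher numbers stand for a stronger effect at the one dose given and lower numbers for a weaker effect), where compound 2 gives 100%, the higher of the two numbers so far. Compound 1 `COCC(C(=O)N1CCN(c2cccc(C(F)(F)F)c2)CC1)N1C(=O)CCC1=O` gives 25% in this assay, a far lower number. Compound 3 `CC(C(=O)N1CCN(c2cccc(C(F)(F)F)c2)CC1)N1C(=O)CCC1=O` is not yet measured; it differs from compound 2 in one place: trifluoromethyl in place of fluoro on an aromatic carbon. Among the compounds with values here, no measured pair covers this single change. A decrease beyond the usual scatter is expected, since compound 1 also carries trifluoromethyl and gives 25%. Compound 3 is expected to reach about 60%, within 25% to 100%. The estimated step is a number 40 percentage points lower from compound 2 to compound 3 (beyond the scatter).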

Compound 3, a percentage reported as activity, at one dose (the size of the read-out at that dose, not a potency): 75%
Beside the measured number, compound 3's estimate is 15 percentage points below it; the measured number falls inside the stated range.
By their numbers in this assay, from the lowest: compound 1; then compound 3; then compound 2.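

On the aromatic ring, trifluoromethyl in place of fluoro lowers the number in this assay, with a number 25 percentage points lower from compound 2 to compound 3 (beyond the scatter), but a clear effect remains. The chain carbon shows the larger step: hydrogen in place of methoxy gives a number 50 percentage points higher from compound 1 to compound 3 (beyond the scatter), so trifluoromethyl alone does not bring the number down as far as it stands for compound 1. No measurement here explains either step. The compounds shown leave open how a chlorine atom or a nitrile on that aromatic carbon, or an ethyl group on that chain carbon, would read.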